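The source may report more compounds than this note shows. Statements on the series, on what has been measured and on what is new or still open speak of the compounds shown alone.

In a functional assay on SK-OV-3 cells (Homo sapiens) for antiproliferative activity, read by MTT assay, with a stated time of 24 h (a higher number here means a weaker inhibitor, a lower number a stronger inhibitor), compound 1 `COc1ccc(C(=O)/C=C/c2ccc([N+](=O)[O-])cc2)c2c1C=CC(C)(C)O2` gives 3420 nM and compound 3 `COc1ccc(C(=O)/C=C/c2ccc(Cl)c(Cl)c2)c2c1C=CC(C)(C)O2` gives 9940 nM, the higher of these two numbers. Compound 2 `COc1ccc(C(=O)/C=C/c2ccsc2)c2c1C=CC(C)(C)O2` gives > 10000 nM, which is a limit of the assay and not a number. Compound 4 `COc1ccc(C(=O)/C=C/c2ccccc2Cl)c2c1C=CC(C)(C)O2` has 2-chlorophenyl in place of the 3,4-dichlorophenyl of compound 3: 2-chlorophenyl in place of 3,4-dichlorophenyl on a double-bonded chain carbon bound to a double-bonded chain carbon. The nearest evidence comes from group swaps at the same place, on a double-bonded chain carbon bound to a double-bonded chain carbon. These are a 2.9-fold higher number from compound 1 to compound 3 (0.46 log units; beyond the scatter) and an at least 2.9-fold higher number from compound 1 to compound 2 (0.46 log units; beyond the scatter), both modest. With swaps of that modest size as the guide, a smaller change between two chlorophenyl groups seems likely, so the expected step is a 1.2-fold lower number from compound 3 to compound 4 (0.09 log units; within the scatter), not beyond the scatter. For compound 4 the estimate is 8000 nM, with an expected range of 3000 nM to 20000 nM.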

Compound 4, half-maximal inhibitory concentration: > 10000 nM
Compound 4 ended at the assay's limit (the forecaster's own chance of this, stated with the estimate: 25%); at least 1.2-fold (0.09 log units) between middle value and limit.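

At this place, on a double-bonded chain carbon bound to a double-bonded chain carbon, 2-chlorophenyl gives a weaker inhibitor than the 4-nitrophenyl group: an at least 2.9-fold higher number from compound 1 to compound 4 (0.46 log units; beyond the scatter). With compound 3, this means that neither chlorophenyl group shown matches compound 1. Against the 3,4-dichlorophenyl group, only a direction can be given: a number no lower from compound 3 to compound 4 (the limit leaves the size open). The step to compound 4 from compound 2 cannot be read, because it runs between two limits: the limit of > 10000 nM in this assay, at which 2 of the 4 values shown sit.

Still open, from the compounds shown here alone, is whether the nitro group itself accounts for the better number of compound 1. A phenyl ring carrying an amine or a carboxylic acid in its place would test this.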